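The source may report more compounds than this note shows. Statements on the series, on what has been measured and on what is new or still open speak of the compounds shown alone.

Compound 1, `C#CCSc1nc(Nc2ccccc2)c2ccncc2n1`: in a functional assay on PC-3 cells (Homo sapiens) for inhibition, read by MTT assay, with a stated time of 72 h (a higher number here means a weaker inhibitor, a lower number a stronger inhibitor), compound 1 gives > 80000 nM, which is a limit of the assay and not a number.
Compound 2, `C#CCSc1nc(Nc2ccc(F)cc2)c2ccncc2n1`: in this assay compound 2 gives 17300 nM.
Compound 3, `C#CCSc1nc(Nc2ccc(Cl)cc2)c2ccncc2n1`: in this assay compound 3 gives 19000 nM.

Within the data shown here, compound 3 holds the highest of the two numbers recorded, but its only neighbour with a number is compound 2, and the step of a 1.1-fold higher number from compound 2 to compound 3 (0.04 log units; within the scatter) leaves the two compounds indistinguishable. The unmeasured compound 4, `C#CCSc1nc(Nc2ccccc2O)c2ccncc2n1`, differs from compound 3 in one place: 2-hydroxyphenyl in place of 4-chlorophenyl on a nitrogen on an aromatic ring.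

Among the measured compounds shown here, two measured steps bear on this change, both in the same direction. The step of an at least 4.2-fold lower number from compound 1 to compound 3 (0.62 log units; beyond the scatter) and the step of an at least 4.6-fold lower number from compound 1 to compound 2 (0.66 log units; beyond the scatter) show that putting a halogen on the phenyl ring takes the number down from compound 1, whose value sits at the limit of > 80000 nM in this assay, at which 1 of the 3 values shown sits. Compound 4 carries no halogen, so by that reading it loses what compound 2 and compound 3 gained. For the measured compounds named here, no compound in the set carries a hydroxyl on the phenyl ring, so the hydroxyphenyl itself is untested here. On balance a rise in the number is expected, of the size a 2.6-fold higher number from compound 3 to compound 4 (0.42 log units; beyond the scatter), with a fair chance that only a limit is recorded. Compound 4 is therefore estimated at 50000 nM in this assay, within 15000 nM to 160000 nM.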

Compound 4, half-maximal inhibitory concentration: 18700 nM
Beside the measured number, compound 4's estimate is 2.7-fold (0.43 log units) above it, and the stated range covers the measured number.
By their numbers in this assay, from the lowest: compounds 2, 4 and 3 (each within the scatter of the next). At a limit, above all of these: compound 1.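

At this position a halogen on the phenyl ring turns out not to be required for the drop away from compound 1, as a hydroxyl on that ring gives an at least 4.2-fold lower number from compound 1 to compound 4 (0.63 log units; beyond the scatter). In this assay, exchanging 4-chlorophenyl for 2-hydroxyphenyl gives a 1.0-fold lower number from compound 3 to compound 4 (0.01 log units; within the scatter) and exchanging 4-fluorophenyl for it gives a 1.1-fold higher number from compound 2 to compound 4 (0.03 log units; within the scatter), so compounds 2, 3 and 4 cannot be told apart, even though 2-hydroxyphenyl counts a hydrogen-bond donor and a hydrogen-bond acceptor that 4-chlorophenyl does not. The drop from compound 1 can be stated only as a minimum, and compound 1 stands at a limit and not at a number: the limit of > 80000 nM in this assay, at which 1 of the 4 values shown sits.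

The compounds shown leave open whether the place of the group on the phenyl ring matters at all, which a 4-hydroxyphenyl or a 2-chlorophenyl on the same nitrogen would test directly. They also leave open whether a different kind of group on that ring, such as an amine, a methoxy or a carboxylic acid, would take the number clearly away from the level that these three compounds share.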